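Swapping the Aryl Group on the Ring Nitrogen

The source may report more compounds than this note shows. Statements on the series, on what has been measured and on what is new or still open speak of the compounds shown alone.

Of the compounds shown here, three sharing one core have been measured in a functional assay on SJSA-1 cells (Homo sapiens) for inhibition, read by CCK-8 assay, with a stated time of 72 h, tested at 1 uM; on this read-out lower numbers stand for less inhibition and higher numbers for more inhibition at the one concentration tested (going by the name of the read-out). Compound 1 `COc1ccccc1N1C(=O)C(C)SC1c1cccc(C(=O)NCCCCc2ccccc2)c1` gives 84%. Compound 3 `CCOc1ccccc1N1C(=O)C(C)SC1c1cccc(C(=O)NCCCCc2ccccc2)c1` gives 85%, and the step of a number 1 percentage points higher from compound 1 to compound 3 (within the scatter) shows that this change made no difference worth noting. Compound 2 `COc1cccc(OC)c1N1C(=O)CSC1c1cccc(C(=O)NCCCCc2ccccc2)c1` gives 72%, the lowest of the three numbers; both compound 1 and compound 3 lie beyond the scatter above it.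

Compound 4 `CC(F)(F)c1cccc(N2C(=O)CSC2c2cccc(C(=O)NCCCCc3ccccc3)c2)c1` has not yet been measured. It differs from compound 2 in one place: a group of 10 heavy atoms (8 carbon, 2 fluorine; one six-membered aromatic ring of carbon only) in place of a group of 10 heavy atoms (8 carbon, 2 oxygen; one six-membered aromatic ring of carbon only), on an amide-type nitrogen in a ring. Within the data shown here, the only measured step, a number 1 percentage points higher from compound 1 to compound 3 (within the scatter), concerns a methyl on a saturated chain carbon and does not touch the group on the amide-type nitrogen, so no measured step bears directly on this change. Compound 1 and compound 3 carry a different group on that nitrogen and sit higher than compound 2, but no single-point comparison isolates that group. The step expected in this assay is therefore a number 5 percentage points higher from compound 2 to compound 4 (within the scatter), small and uncertain. Compound 4 is estimated at 77%, with a range from 60% to 92%.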

Compound 4, a percentage reported as inhibition, at one concentration (the size of the read-out at that concentration, not a potency): 68%
Compound 4: the middle estimate sits 9 percentage points above what was measured; the range from low to high includes it.
By their numbers in this assay, from the lowest: compounds 4 and 2 (each within the scatter of the next); then compounds 1 and 3 (each within the scatter of the next).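

In this assay, putting the group with 8 carbon and 2 fluorine atoms on the amide-type nitrogen in place of 2,6-dimethoxyphenyl gives a number 4 percentage points lower from compound 2 to compound 4 (within the scatter), the first step read at this position. For this pair, a group with 0 hydrogen-bond acceptors replaces one with 2 without moving the number beyond the usual scatter of the assay. No supporting measurement bears on this result, so what lies behind it remains unexplained.

From the compounds shown here alone, compound 1 and compound 3 differ from compound 2 in more than one place, and the part played by their aryl group alone stays open. Going by these compounds, it is also open how an unsubstituted phenyl group, or a phenyl ring carrying an amine or a carboxylic acid, would read on this nitrogen.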